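Imide Replaces Benzylmethylamine on the Shared Core

The source may hold more compounds than are shown below. What is called first, only, known or untested is meant among the compounds shown, and "the series" means these compounds.

In an in vitro assay on UC11MG cells for binding affinity to Substance-P receptor (Homo sapiens), read by radioligand binding (on this read-out lower numbers stand for stronger inhibition and higher numbers for weaker inhibition), compound 1 `NCc1nc2ccccc2c(-c2ccccc2)c1C(=O)NCc1cc(C(F)(F)F)cc(C(F)(F)F)c1` gives 0.0017 nM, while compound 2 `CN(Cc1ccccc1)Cc1nc2ccccc2c(-c2ccccc2)c1C(=O)NCc1cc(C(F)(F)F)cc(C(F)(F)F)c1` gives 180 nM, the higher of the two numbers, the step being a 110000-fold higher number from compound 1 to compound 2 (5.02 log units; beyond the scatter). Compound 3 `O=C(NCc1cc(C(F)(F)F)cc(C(F)(F)F)c1)c1c(CN2C(=O)c3ccccc3C2=O)nc2ccccc2c1-c1ccccc1` differs from compound 2 by a group of 11 heavy atoms (8 carbon, 1 nitrogen, 2 oxygen; one five-membered non-aromatic ring with 1 hetero atom, one six-membered aromatic ring of carbon only) in place of a group of 9 heavy atoms (8 carbon, 1 nitrogen; one six-membered aromatic ring of carbon only), on a saturated chain carbon bound to an aromatic carbon. Going by the values given here, the single measured step at this position, a 110000-fold higher number from compound 1 to compound 2 (5.02 log units; beyond the scatter), was large and went toward weaker binding when the small amino group was enlarged. Since compound 3 carries a group of comparable size there, the step of a 2.8-fold higher number from compound 2 to compound 3 (0.44 log units; beyond the scatter) is expected to stay roughly within the scatter. Compound 3 is therefore estimated at 500 nM, ranging from 50 nM to 5000 nM.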

Compound 3, half-maximal inhibitory concentration: > 1000 nM
Compound 3: no number, only a limit; the forecaster's own chance of this, stated with the estimate: 10%; middle value at least 2.0-fold (0.30 log units) away from the limit.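

In this assay compound 3 is held only as a limit, not a number: the limit of > 1000 nM in this assay, at which 1 of the 3 values shown sits. Even so, the larger ring-bearing group on this saturated chain carbon gives an at least 5.5-fold higher number from compound 2 to compound 3 (0.74 log units; beyond the scatter), so a second bulky replacement also sits on the weak side. Measured against the small amino group, the change is an at least 580000-fold higher number from compound 1 to compound 3 (5.76 log units; beyond the scatter), which leaves amino as the only group shown here with strong binding. How far the true value of compound 3 lies past its limit cannot be read. Going by these compounds, whether methylamino, dimethylamino or a longer chain ending in an amine would keep the low number of the amino group stays open.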